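A Cyanophenyl in Place of a Methylsulfonylpiperidinyl Group

The compounds below may be only part of what the source reports. "The series", "measured", "known", "first", "only" and "open" are said of these compounds alone.

Three compounds have so far been measured in an in vitro functional assay on HEK293S cells with Glucose-dependent insulinotropic receptor (Homo sapiens) as the target, read by HTRF and cAMP accumulation, with a stated time of 45 min; on this read-out lower numbers stand for smaller maximal responses and higher numbers for larger maximal responses:

Compound 1, `C[C@H]1CN(c2ncc(OCc3ccc(S(C)(=O)=O)cc3)cn2)CCN1C(=O)OC(C)(C)C`, gives 163%.
Compound 2, `CC(C)(C)OC(=O)N1C[C@@H]2CC[C@H]1CN2c1ncc(OCc2ccc(S(C)(=O)=O)cc2)cn1`, gives 85%.
Compound 3, `C[C@@H]1CN(C(=O)OC(C)(C)C)CCN1c1ncc(OCC2CCN(S(C)(=O)=O)CC2)cn1`, gives 99%.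

Among these three numbers compound 3 holds the second highest place. Its nearest neighbour is compound 2, whose number lies lower by a margin beyond the usual scatter, so compound 3 reaches the larger maximal response of the two. Compound 1 is the furthest away, with a number that is higher by a margin well beyond the scatter.

The next compound to be measured is compound 4, `C[C@@H]1CN(C(=O)OC(C)(C)C)CCN1c1ncc(OCc2ccc(C#N)cc2)cn1`. It differs from compound 3 in one place: 4-cyanophenyl in place of 1-(methylsulfonyl)piperidin-4-yl on a saturated chain carbon bound to an oxygen on an aromatic ring. The group that leaves is a saturated ring carrying a methylsulfonyl on its nitrogen; the group that enters is a flat aromatic ring with a nitrile.

Going by the values given here, no measured pair shows this exact exchange, so the size of the step in this assay has to be guessed. A modest rise is expected, though one that may not clear the scatter. Compound 4 is therefore estimated at 110%, within 70% to 160%, which corresponds to an expected step of a number 11 percentage points higher from compound 3 to compound 4 (beyond the scatter).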

Compound 4, intrinsic activity: the largest response reached, in percent of the reference agonist's: 141%
Compound 4: the middle estimate sits 31 percentage points below what was measured; the range from low to high includes it.
By their numbers in this assay, from the lowest: compound 2; then compound 3; then compound 4; then compound 1.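

In this assay, the group on a saturated chain carbon bound to an oxygen on an aromatic ring proves able to shift the maximal response, since 4-cyanophenyl in place of 1-(methylsulfonyl)piperidin-4-yl gives a number 42 percentage points higher from compound 3 to compound 4 (beyond the scatter) in a large step. Going by these compounds alone, this is the first pair that differs in one place only, so the earlier compounds could not isolate the effect of any single change. No measurement on hand accounts for this step.

Within the data shown here, the exchange alters two things at once, removing a six-membered non-aromatic ring with its methylsulfonyl and bringing in an aromatic ring of carbon only with its nitrile, so the single step cannot say which of these matters. An unsubstituted phenyl at this place would separate the ring from the nitrile, while a 4-carboxyphenyl or a 4-aminophenyl would show how much the response depends on the particular group carried by that ring.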